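The compounds below may be only part of what the source reports. "The series", "measured", "known", "first", "only" and "open" are said of these compounds alone.

Measured compounds:
compound 1, `Nc1nc(Cl)c2ncn(Cc3ccccc3CCl)c2n1`: 20900 nM
compound 2, `ClCc1cccc(Cn2cnc3nc(Cl)nc(Cl)c32)c1`: 400 nM
compound 3, `Nc1nc(Cl)c2ncn(Cc3cccc(CCl)c3)c2n1`: 19100 nM

In a functional assay on SK-MEL-28 cells (Homo sapiens) for cytotoxicity, read by sulforhodamine B assay, with a stated time of 48 h (on this read-out higher numbers stand for weaker inhibition of growth and lower numbers for stronger inhibition of growth), compound 2 gives 400 nM, the lowest of the three numbers. Compound 3 gives 19100 nM and compound 1 gives 20900 nM, both beyond the scatter above compound 2. Compound 4, `ClCc1cccc(Cn2cnc3ncnc(Cl)c32)c1`, has not yet been measured. It differs from compound 2 by hydrogen in place of chloro on an aromatic carbon. Going by the values given here, no pair of measured compounds differs in this single way, so the size of such a step is not known from these data; the dichloro compound 2 stands alone among the measured set. A moderate loss is expected for compound 4, a step of a 5.0-fold higher number from compound 2 to compound 4 (0.70 log units; beyond the scatter). Compound 4 is estimated at 2000 nM, with a range from 500 nM to 8000 nM.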

Compound 4, concentration for total growth inhibition: 3540 nM
Estimate against measurement, compound 4: 1.8-fold (0.25 log units) below; measured number inside the range.
By their numbers in this assay, from the lowest: compound 2; then compound 4; then compounds 3 and 1 (each within the scatter of the next).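

In this assay, replacing the chloro on the aromatic carbon between two ring nitrogen atoms with hydrogen gives an 8.9-fold higher number from compound 2 to compound 4 (0.95 log units; beyond the scatter), the first single-place change among these compounds. It shows that this chloro contributes measurably to growth inhibition, yet the step is modest and compound 4 still gives a value in the low micromolar range. No measurement here explains the step.

As far as these compounds go, what remains open is whether a fluoro, a bromo or a methoxy group at this carbon would match chloro or hydrogen. Also open, from the compounds shown here alone, is how a methyl group there would compare.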